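This account rests on a few compounds, and the source may have more. Where it says the series, first, only, none or still open, it means among the compounds named here.

Compound 1 `Nc1nc2ccc(I)cc2s1`, compound 2 `Nc1nc2ccc(OC(F)(F)C(F)F)cc2s1` and compound 3 `C=CCn1c(=N)sc2cc(OC(F)(F)F)ccc21` share a core and were tested in a functional assay on the whole organism with Rattus norvegicus as the target; a higher number here means that more compound is needed for the effect, a lower number that less compound is needed. For compound 1 the result in this assay is only a limit of the assay, > 10 mg/kg, not a number. Compound 2 gives 8.5 mg/kg in this assay. Compound 3 gives 7 mg/kg in this assay, the lower of the two numbers recorded, though its gap to compound 2 lies within the usual scatter, so the two cannot be told apart on these data.

Compound 4 `C[S+]([O-])Cn1c(=N)sc2cc(OC(F)(F)F)ccc21` has not yet been measured in this assay. Its structure differs from compound 3 in one place: a group of 3 heavy atoms (1 carbon, 1 oxygen, 1 sulfur; no ring) in place of a group of 2 heavy atoms (2 carbon; no ring), on a saturated chain carbon bound to an aromatic nitrogen. The vinyl group leaves and a group with no common name takes its place on the saturated chain carbon bound to the aromatic nitrogen; the rest of the molecule is kept as it is.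

Going by the values given here, no pair of measured compounds differing in a single place is available to show how such a change moves the dose, so the expectation for the step of a 1.1-fold higher number from compound 3 to compound 4 (0.06 log units; within the scatter) is one of no change beyond the scatter. Compound 4 is therefore expected to give about 8 mg/kg in this assay, in a range from 4 mg/kg to 16 mg/kg.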

Compound 4, dose for half-maximal effect: 2.3 mg/kg
For compound 4 the middle estimate is 3.5-fold (0.54 log units) above the measured one; measured number below the stated range.
By their numbers in this assay, from the lowest: compound 4; then compounds 3 and 2 (each within the scatter of the next). At a limit, above all of these: compound 1.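

Exchanging the vinyl group for the group with no common name, which holds one carbon, one oxygen and one sulfur, on a saturated chain carbon bound to an aromatic nitrogen gives a 3.0-fold lower number from compound 3 to compound 4 (0.48 log units; beyond the scatter) in this assay. Going by these compounds alone, this is the first comparison in the set that isolates a single place, and it shows that this position affects the dose: the step is modest but beyond the scatter, and less compound is needed after the change. The change removes a double bond outside aromatic rings and adds a hydrogen-bond acceptor, but nothing measured here explains the step.

A single step cannot separate the contributions of the lost double bond, the sulfur and the oxygen, and it cannot show whether a simple methyl, a longer chain, an amine or a carboxylic acid at this position would shift the dose in the same direction. It also leaves open whether the gain would persist if the trifluoromethyl-bearing group on the rest of the molecule were replaced by another group.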